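The source may hold more compounds than are shown below. What is called first, only, known or untested is meant among the compounds shown, and "the series" means these compounds.

Three compounds share one core and were tested in a functional assay on B16-F10 cells (Mus musculus) for inhibition, read by MTT assay, with a stated time of 72 h; a lower number here means a stronger inhibitor, a higher number a weaker inhibitor. Compound 1 `CC(C)c1ccc(-c2nc(SCc3cn(CC(=O)NC(=O)Nc4ccccn4)nn3)nc(Nc3cccc(Cl)c3)c2C#N)cc1` gives 1130 nM. Compound 2 `Cc1ccc(Nc2nc(SCc3cn(CC(=O)NC(=O)Nc4ccccn4)nn3)nc(-c3ccc(C(C)C)cc3)c2C#N)cc1` gives 3060 nM. Compound 3 `Cc1ccc(Nc2nc(SCc3cn(CC(=O)NC(=O)Nc4ccccn4)nn3)nc(-c3ccc(C)cc3)c2C#N)cc1` gives 1010 nM. Compound 1 and compound 3 lie within the scatter of each other, so nothing separates them.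

Two changes are seen. From compound 2 to compound 1 (3-chlorophenyl in place of 4-methylphenyl on a nitrogen on an aromatic ring), and the step was a 2.7-fold lower number from compound 2 to compound 1 (0.43 log units; beyond the scatter). From compound 2 to compound 3 the cores differ (methyl in place of isopropyl on an aromatic carbon), and the step was a 3.0-fold lower number from compound 2 to compound 3 (0.48 log units; beyond the scatter).

Compound 4 `Cc1ccc(-c2nc(SCc3cn(CC(=O)NC(=O)Nc4ccccn4)nn3)nc(Nc3cccc(Cl)c3)c2C#N)cc1` has not yet been measured. It differs from compound 3 in the same place and kind of change (3-chlorophenyl in place of 4-methylphenyl on a nitrogen on an aromatic ring), the same change that turned compound 2 into compound 1, though here the rest of the core carries methyl rather than isopropyl.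

The expectation for compound 4 rests on a single prior instance, so it is tentative: a step of a 2.2-fold lower number from compound 3 to compound 4 (0.35 log units; beyond the scatter) from compound 3 is estimated, set beside the earlier one because a 2.7-fold lower number from compound 2 to compound 1 (0.43 log units; beyond the scatter) was modest and beyond the scatter. Compound 4 is therefore expected to give about 450 nM in this assay, between 200 nM and 1100 nM.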

Compound 4, half-maximal inhibitory concentration: 7580 nM
Beside the measured number, compound 4's estimate is 17-fold (1.23 log units) below it; the measured number lies above the stated range.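

On the core carrying methyl, 3-chlorophenyl in place of 4-methylphenyl gave a 7.5-fold higher number from compound 3 to compound 4 (0.88 log units; beyond the scatter) in this assay, so the change that helped on the core carrying isopropyl does not carry over, and its direction reverses: the same change on two cores in this assay, a 2.7-fold lower number (0.43 log units; beyond the scatter) from compound 2 to compound 1 and a 7.5-fold higher number (0.88 log units; beyond the scatter) from compound 3 to compound 4, 20-fold (1.31 log units) apart, beyond the scatter of two such steps Read the other way, methyl in place of isopropyl gave a 6.7-fold higher number from compound 1 to compound 4 (0.83 log units; beyond the scatter) when the nitrogen carries 3-chlorophenyl, which is likewise the reverse of what it did when the nitrogen carries 4-methylphenyl: the same change on two cores in this assay, a 3.0-fold lower number (0.48 log units; beyond the scatter) from compound 2 to compound 3 and a 6.7-fold higher number (0.83 log units; beyond the scatter) from compound 1 to compound 4, 20-fold (1.31 log units) apart, beyond the scatter of two such steps These four compounds show that the effect of each change depends on the group present at the other place, but they do not show why, and this single set cannot say how either change would behave on any other core.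

The compounds shown leave open whether the reversal would persist with a bromine or a methoxy group in place of the chlorine. They also leave open what an ethyl group would do in place of the methyl or isopropyl.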